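A Fluorine Step Carried Onto a Second Core

A few compounds are considered here, and "the series" means these few. Any claim that something is new, unique, unknown or untested is made for them only; others in the source may bear on it.

Compound 1 `CC(=N)Nc1cccc(C(=O)NNC(=O)CC(CC(=O)O)c2ccccc2)c1` is measured in a physicochemical assay for lipophilicity (a higher number here means a more lipophilic compound, a lower number a more polar compound), and gives 1.44. Compound 2 `CC(=N)Nc1cccc(C(=O)NNC(=O)CC(CC(=O)O)c2ccc(F)cc2)c1` differs from compound 1 by fluoro in place of hydrogen on an aromatic carbon and in this assay compound 2 gives 1.6, a step of a number 0.16 log units higher from compound 1 to compound 2 (within the scatter). Compound 3 `O=C(O)CC(CC(=O)NNC(=O)CCCCNc1ccccn1)c1ccccc1` is built on another core; the difference between the two cores is not broken down here. In this assay compound 3 gives 2.07, the highest of the three numbers and beyond the scatter from both compound 1 and compound 2. Compound 4 `O=C(O)CC(CC(=O)NNC(=O)CCCCNc1ccccn1)c1ccc(F)cc1` carries the same change on the core of compound 3, (fluoro in place of hydrogen on an aromatic carbon), the change also seen between compound 1 and compound 2. The step from compound 3 to compound 4 is expected to be a number 0.16 log units higher from compound 3 to compound 4 (within the scatter), resting on a number 0.16 log units higher from compound 1 to compound 2 (within the scatter). For compound 4 the estimate is 2.23, between 1.95 and 2.5.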

Compound 4, partition coefficient: 2.23
For compound 4 middle estimate and measured number coincide at the digits printed, and the stated range covers the measured number.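

In this assay the fluoro in place of hydrogen on an aromatic carbon gives a number 0.16 log units higher from compound 3 to compound 4 (within the scatter) on the second core, and on the first core it gave a number 0.16 log units higher from compound 1 to compound 2 (within the scatter) in a step of the same size. This shows that the change behaves alike on these two cores, but with both steps within the scatter, neither pair can be told apart from no change at all, and two pairs make no rule for the series. Nothing shown here speaks to what lies behind the result.

Going by these compounds, whether chloro or methoxy in place of the fluoro would carry across in the same way stays open. So does the same change on a core with an amine in place of the carboxylic acid, or with a shorter chain than the one in compound 3.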